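This account rests on a few compounds, and the source may have more. Where it says the series, first, only, none or still open, it means among the compounds named here.

Working notes on the series.

Three compounds share one core and differ only in the aryl group carried on the ring nitrogen. In a functional assay on CWR22R cells (Homo sapiens) for inhibition, with a stated time of 120 h, tested at 10 uM (on this read-out higher numbers stand for more inhibition at the one concentration tested (going by the name of the read-out) and lower numbers for less inhibition), compound 1 `Cc1n[nH]c2ccc(-c3nc4cnc(N5CCN(C)CC5)cn4c3Nc3ccccc3Cl)cc12` gives "not determined" (no result reported), and compound 2 `Cc1n[nH]c2ccc(-c3nc4cnc(N5CCN(C)CC5)cn4c3Nc3cccc(Cl)c3)cc12` gives "not determined" (no result reported). Among the compounds with values here, compound 3 `Cc1n[nH]c2ccc(-c3nc4cnc(N5CCN(C)CC5)cn4c3Nc3ccc(F)cc3Br)cc12` is the only member with a number: in this assay compound 3 gives 4.41%, a read-out close to no inhibition at the single concentration tested. Within the data shown here, with two of three entries empty, compound 3 stands alone, and no step between measured compounds can be drawn; nothing in these data shows how the aryl group moves the read-out.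

Compound 4 `COc1ccc(Nc2c(-c3ccc4[nH]nc(C)c4c3)nc3cnc(N4CCN(C)CC4)cn23)cc1OC` is the next entry to be tested. Against compound 3 the difference is 3,4-dimethoxyphenyl in place of 2-bromo-4-fluorophenyl on a nitrogen on an aromatic ring. Among the measured compounds shown here, with no comparable pair measured, the size of this step is unknown, and given the low read-out of compound 3 4.41% the expectation is a step from compound 3 to compound 4 of about a number 5.6 percentage points higher from compound 3 to compound 4 (within the scatter), likely within the scatter. Compound 4 is estimated to give 10% in this assay, with a range of -5% to 35%.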

Compound 4, a percentage reported as inhibition, at one concentration (the size of the read-out at that concentration, not a potency): 0%
Beside the measured number, compound 4's estimate is 10 percentage points above it; low and high end bracket the measured number.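

In this assay, within the data shown here, the first readable step at this position is a number 4.4 percentage points lower from compound 3 to compound 4 (within the scatter) and it shows that 3,4-dimethoxyphenyl and 2-bromo-4-fluorophenyl on a nitrogen on an aromatic ring cannot be told apart. Among these compounds, an aryl group with two oxygen-bearing substituents and one with two halogens therefore give the same picture at the one concentration tested, where the earlier compounds offered no pair at all. Nothing measured bears on the reason for this result.

Steps involving compound 1 and compound 2 cannot be read, so the aryl groups of those two compounds remain without a comparison. Going by these compounds, what an aryl group carrying an amine or a carboxylic acid on this nitrogen would give in this assay also stays open.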